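This account rests on a few compounds, and the source may have more. Where it says the series, first, only, none or still open, it means among the compounds named here.

Measured compounds:
compound 1 `CCn1cc(C(=O)O)c(=O)c2cc(F)c(N3CCN(C(=N)NS(=O)(=O)c4ccc(C(F)(F)F)cc4)CC3)cc21`: 43 nM
compound 2 `N=C(NS(=O)(=O)c1ccc(C(F)(F)F)cc1)N1CCN(c2cc3c(cc2F)c(=O)c(C(=O)O)cn3C2CC2)CC1`: 43 nM

Going by the values given here, in a functional assay on HL-60 cells (Homo sapiens) for antiproliferative activity, read by MTT assay, with a stated time of 72 h (a higher number here means a weaker inhibitor, a lower number a stronger inhibitor), compound 1 gives 43 nM and stands level with compound 2, the only other measured compound, with no change at the digits printed from compound 1 to compound 2 (within the scatter) for cyclopropyl in place of ethyl on an aromatic nitrogen. Compound 3 `CCn1cc(C(=O)O)c(=O)c2cc(F)c(N3CCN(C(=N)NS(=O)(=O)c4ccc(Cl)cc4)CC3)cc21` differs from compound 1 by chloro in place of trifluoromethyl on an aromatic carbon. Among the compounds with values here, no measured step touches the sulfonyl aryl group, so nothing here sets the size of this change, and the one known step leaves the shared core tolerant of a single substitution. The expectation is therefore a step of a 1.0-fold higher number from compound 1 to compound 3 (0.02 log units; within the scatter), within the scatter, and compound 3 is estimated at 45 nM (range 15 nM to 140 nM).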

Compound 3, half-maximal inhibitory concentration: 43 nM
The estimate for compound 3 lay 1.0-fold (0.02 log units) above the measured number; the measured number falls inside the stated range.
By their numbers in this assay, from the lowest: compounds 1, 2 and 3 (each within the scatter of the next).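

Going by these compounds alone, the exchange of 4-(trifluoromethyl)phenyl for 4-chlorophenyl in this assay gives no change at the digits printed from compound 1 to compound 3 (within the scatter) and is the first reading at the sulfonyl aryl group, as the earlier step touched only the aromatic nitrogen. This aromatic carbon, para to a large group, therefore tolerates chloro in place of trifluoromethyl on the core of compound 1. No available evidence bears on why the two groups read alike.

On these data alone, whether an amine, a methoxy group or a carboxylic acid at this carbon would read the same remains open. Also open, as far as these compounds go, is whether chloro in place of trifluoromethyl reads the same on compound 2, which carries cyclopropyl on the aromatic nitrogen.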